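The source may hold more compounds than are shown below. What is called first, only, known or untested is meant among the compounds shown, and "the series" means these compounds.

In an ADME assay on MT4 cells (Homo sapiens) for cytotoxicity, read by MTT assay, with a stated time of 96 h (a lower number here means that less compound is tolerated, a higher number that more compound is tolerated), compound 2 `Cc1ccc(C2CC(c3ccccc3)=NN2c2ccc(S(N)(=O)=O)cc2)cc1` gives 40000 nM and compound 1 `NS(=O)(=O)c1ccc(N2N=C(c3ccccc3)CC2c2ccccc2F)cc1` gives 42000 nM which places the two within the scatter of each other. Among the compounds with values here, compound 3 `NS(=O)(=O)c1ccc(N2N=C(c3ccccc3)CC2c2ccccc2Cl)cc1` has no measurement yet. Its change from compound 2 is 2-chlorophenyl in place of 4-methylphenyl on a saturated ring carbon, and the count for that swap reads 2-chlorophenyl in place of 4-methylphenyl on a saturated ring carbon in full. Within the data shown here, one measured step bears on it: a swap on that same carbon gave a 1.1-fold lower number from compound 1 to compound 2 (0.02 log units; within the scatter) and so stayed within the scatter. Among the measured compounds shown here, with that single small step as the only guide, and no measured step that tests chlorine, no move beyond the scatter is expected in this assay here. The expected size, no change at the digits printed from compound 2 to compound 3 (within the scatter) in all, carries no firm direction. Compound 3 is estimated to give about 40000 nM with 18000 nM to 90000 nM as the expected span.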

Compound 3, half-maximal cytotoxic concentration: 44000 nM
The estimate for compound 3 lay 1.1-fold (0.04 log units) below the measured number; the measured number falls inside the stated range.
By their numbers in this assay, from the lowest: compounds 2, 1 and 3 (each within the scatter of the next).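

In this assay, within the data shown here, the swap of 4-methylphenyl for 2-chlorophenyl on the saturated ring carbon gives a 1.1-fold higher number from compound 2 to compound 3 (0.04 log units; within the scatter) and, as the first change confined to the halogen, chloro in place of fluoro on an aromatic carbon gives a 1.0-fold higher number from compound 1 to compound 3 (0.02 log units; within the scatter) as its result. The three groups tried on this carbon, 2-fluorophenyl, 4-methylphenyl and 2-chlorophenyl, therefore all stand within the scatter of one another. Nothing available explains this lack of separation.

As far as these compounds go, all three groups are substituted phenyl rings, so whether an amine, a carboxylic acid or a longer alkyl chain on that carbon would shift the number beyond the scatter stays open. Also open, from the compounds shown here alone, is what a pyridine ring would do in place of the phenyl group elsewhere on the shared core.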